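This account rests on a few compounds, and the source may have more. Where it says the series, first, only, none or still open, it means among the compounds named here.

Notes on the series. Compound 1 `CCCn1nc(C)c2c(C)cc(=O)oc21` gives 54.3 mg/kg in a functional assay on the whole organism with Mus musculus as the target, in the writhing test; a lower number here means that less compound is needed, a higher number that more compound is needed for the effect. Compound 2 `CCOC(=O)Cc1nn(C)c2oc(=O)cc(C)c12` reaches only a limit in this assay: compound 2 gives > 100 mg/kg, which is a limit of the measurement and not a number. Compound 3 `CCN(CC)CCn1nc2oc(=O)cc(C)c2c1C` gives 100 mg/kg in this assay; the difference to compound 1 lies within the scatter, so the two numbers are not separated by the measurements at hand. Compound 4 `Cc1cc(=O)oc2nn(CCO)c(C)c12` has not yet been measured. It differs from compound 3 by hydroxy in place of diethylamino on a saturated chain carbon, two bonds along the chain from an aromatic nitrogen. Among the measured compounds shown here, no pair of measured compounds shows this exchange, so the series gives no measured step from which its effect on the dose could be read. Compound 4 is therefore expected to stay close to compound 3, with a 1.2-fold lower number from compound 3 to compound 4 (0.07 log units; within the scatter) amounting to no change beyond the scatter. The estimate for compound 4 in this assay is 85 mg/kg, with a range from 35 mg/kg to 200 mg/kg.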

Compound 4, dose for half-maximal effect: > 100 mg/kg
Compound 4: a limit, no number; the forecaster's own chance of this, stated with the estimate: 35%; middle value at least 1.1-fold (0.07 log units) away from the limit.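

In this assay compound 4 gives > 100 mg/kg, which is a limit of the measurement and not a number. The exchange of diethylamino for hydroxy on a saturated chain carbon, two bonds along the chain from an aromatic nitrogen, now has a measured step, a number no lower from compound 3 to compound 4 (the limit leaves the size open), so hydroxy brings no lowering of the dose at this position. How large the step is cannot be read because the measurement ends at a limit here: the limit of > 100 mg/kg in this assay, at which 2 of the 4 values shown sit.

Going by these compounds, what a carboxylic acid, a primary amine or a longer chain would do at this position stays open. Also open, on these data alone, is whether any group at this position can bring the dose clearly under that of compound 3.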